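A few compounds are considered here, and "the series" means these few. Any claim that something is new, unique, unknown or untested is made for them only; others in the source may bear on it.

Compound 1 `C/C(=C\C=C\c1ccccc1)C1=CC(=O)C(C)(C)O1` and compound 2 `C/C(=C\COC(=O)NC1CCCCC1)C1=CC(=O)C(C)(C)O1` share the same core and have both been tested in a functional assay on MOLT-4F cells (Homo sapiens) for inhibition; on this read-out higher numbers stand for weaker inhibition and lower numbers for stronger inhibition. In this assay compound 1 gives 14 ug/mL, the higher of the two numbers, while compound 2 gives 3.4 ug/mL, a lower number whose distance from compound 1 lies beyond the usual scatter. Compound 3 `COc1ccc(/C=C/C=C(\C)C2=CC(=O)C(C)(C)O2)cc1` keeps the whole of compound 1 and differs in a single place: methoxy in place of hydrogen on an aromatic carbon. The newcomer sits on an aromatic carbon of a six-membered aromatic ring of carbon only, para to a large group. Within the data shown here, no measured pair shows what this particular change does, so the step from compound 1 to compound 3 in this assay is expected to be small, most likely within the scatter, with only a slight lean toward a lower number. For compound 3 a value of 10 ug/mL is expected, with a likely range from 4 ug/mL to 25 ug/mL. That expectation amounts to a step of a 1.4-fold lower number from compound 1 to compound 3 (0.15 log units; within the scatter).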

Compound 3, half-maximal inhibitory concentration: 10 ug/mL
The estimate for compound 3 equals the measured number at the digits printed, and the stated range covers the measured number.
By their numbers in this assay, from the lowest: compound 2; then compounds 3 and 1 (each within the scatter of the next).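

In this assay, methoxy in place of hydrogen on this aromatic carbon, para to a large group, gives a 1.4-fold lower number from compound 1 to compound 3 (0.15 log units; within the scatter). Among these compounds, this is the first direct reading of a change at this position, since compounds 1 and 2 differ in more than one place and could not isolate it; here, the added methoxy leaves a difference that cannot be told apart from ordinary repeat variation. Nothing shown accounts for this result or tells what lies behind it.

From the compounds shown here alone, whether this position responds as little to other groups, such as an amine or a carboxylic acid, remains open. Also open, going by these compounds, is whether methoxy would give a similar result on another carbon of the same ring, as this single pair speaks only to the one position.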